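The source may report more compounds than this note shows. Statements on the series, on what has been measured and on what is new or still open speak of the compounds shown alone.

Measured compounds:

Compound 1, `Cc1ccccc1-n1cc(-c2ccccc2NS(=O)(=O)c2c[nH]c(=O)[nH]c2=O)nn1`, 3210 nM in a functional assay on A549 cells (Homo sapiens) for antiproliferative activity, read by MTT assay, with a stated time of 24 h; a higher number here means a weaker inhibitor, a lower number a stronger inhibitor
Compound 2, `Cc1cccc(-n2cc(-c3ccccc3NS(=O)(=O)c3c[nH]c(=O)[nH]c3=O)nn2)c1`, 1870 nM in this assay
Compound 3, `Cc1ccccc1-n1cc(-c2cccc(NS(=O)(=O)c3c[nH]c(=O)[nH]c3=O)c2)nn1`, 5470 nM in this assay

Compound 4, `Cc1cccc(-n2cc(-c3cccc(NS(=O)(=O)c4c[nH]c(=O)[nH]c4=O)c3)nn2)c1`, has not yet been tested in this assay.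

Compounds 1 and 2 share a core and differ in one place: 3-methylphenyl in place of 2-methylphenyl on an aromatic nitrogen. That change gave a 1.7-fold lower number from compound 1 to compound 2 (0.23 log units; within the scatter), a step too small to be told apart from repeat testing. Compound 3 carries a different core from compound 1; how the two cores differ is not broken down here. Set against the others, compound 3 and compound 1 lie close enough that no order can be claimed between them, while compound 2 stands apart from compound 3 by more than the scatter.

Compound 4 is related to compound 3 by the same change: 3-methylphenyl in place of 2-methylphenyl on an aromatic nitrogen. Going by the values given here, the expected step is a 1.7-fold lower number from compound 3 to compound 4 (0.22 log units; within the scatter), which rests on the single earlier example, a 1.7-fold lower number from compound 1 to compound 2 (0.23 log units; within the scatter), and so carries wide uncertainty. Compound 4 is therefore estimated at 3300 nM. The range expected for compound 4 runs from 1700 nM to 6500 nM.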

Compound 4, half-maximal inhibitory concentration: 3550 nM
Estimate against measurement, compound 4: 1.1-fold (0.03 log units) below; the range from low to high includes it.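

In this assay, putting 3-methylphenyl in place of 2-methylphenyl on the aromatic nitrogen of the core of compound 3 gives a 1.5-fold lower number from compound 3 to compound 4 (0.19 log units; within the scatter). Set beside the earlier step, the change carries over from one core to the other with no difference that can be told apart, and it stays small on both: the same change on two cores in this assay, a 1.7-fold lower number (0.23 log units; within the scatter) from compound 1 to compound 2 and a 1.5-fold lower number (0.19 log units; within the scatter) from compound 3 to compound 4, 1.1-fold (0.05 log units) apart, within the scatter of two such steps This does not show that the change truly makes the compounds stronger, for each step alone is too small to be separated from repeat testing, and two cores cannot speak for any others in the series.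

The compounds shown leave open what a group other than methyl on that phenyl ring, such as a methoxy group, a chlorine atom or an amine, would do in this assay, and whether any of these would give a step beyond the scatter. They also leave open whether the same small step would hold on a third core.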